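Chloro added on a urea aryl ring in a cytotoxicity series

This account rests on a few compounds, and the source may have more. Where it says the series, first, only, none or still open, it means among the compounds named here.

Measured compounds:
compound 1 `CN(C)CCCNc1nc(-c2ccc(NC(=O)Nc3ccccc3Cl)cc2)nc2c(Cl)c(Cl)sc12` — 820 nM
compound 2 `CN(C)CCCNc1nc(-c2ccc(NC(=O)Nc3ccc(Cl)cc3Cl)cc2)nc2c(Cl)c(Cl)sc12` — 1320 nM
compound 3 `CN(C)CCNc1nc(-c2ccc(NC(=O)Nc3ccccc3Cl)cc2)nc2c(Cl)c(Cl)sc12` — 570 nM

Of the compounds shown here, three have been tested in a functional assay on HT-29 cells (Homo sapiens) for cytotoxicity, read by MTT assay, with a stated time of 72 h; on this read-out lower numbers stand for stronger inhibition and higher numbers for weaker inhibition. Compound 1 gives 820 nM, compound 2 gives 1320 nM and compound 3 gives 570 nM. The change from compound 1 to compound 2 is chloro in place of hydrogen on an aromatic carbon, and it made the step of a 1.6-fold higher number from compound 1 to compound 2 (0.21 log units; within the scatter). Compound 1 and compound 3 differ in the core by dimethylamino in place of (dimethylamino)methyl on a saturated chain carbon, two bonds along the chain from a nitrogen on an aromatic ring, with the step of a 1.4-fold lower number from compound 1 to compound 3 (0.16 log units; within the scatter).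

Compound 4 `CN(C)CCNc1nc(-c2ccc(NC(=O)Nc3ccc(Cl)cc3Cl)cc2)nc2c(Cl)c(Cl)sc12` is not yet measured. Its difference from compound 3 is chloro in place of hydrogen on an aromatic carbon, the same change that was made from compound 1 to compound 2. Because that earlier step was a 1.6-fold higher number from compound 1 to compound 2 (0.21 log units; within the scatter), a step of similar size is expected here, namely a 1.6-fold higher number from compound 3 to compound 4 (0.20 log units; within the scatter) in this assay. Compound 4 is therefore estimated at 900 nM, expected to lie between 500 nM and 1700 nM.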

Compound 4, half-maximal inhibitory concentration: 1280 nM
For compound 4 the middle estimate is 1.4-fold (0.15 log units) below the measured one; the range from low to high includes it.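

In this assay, the chloro that turns 2-chlorophenyl into 2,4-dichlorophenyl gave a 2.2-fold higher number from compound 3 to compound 4 (0.35 log units; beyond the scatter), and the two steps for this change agree across the two cores: the same change on two cores in this assay, a 1.6-fold higher number (0.21 log units; within the scatter) from compound 1 to compound 2 and a 2.2-fold higher number (0.35 log units; beyond the scatter) from compound 3 to compound 4, 1.4-fold (0.14 log units) apart, within the scatter of two such steps The swap of (dimethylamino)methyl for dimethylamino on the chain, with the 2,4-dichlorophenyl group in place, gave a 1.0-fold lower number from compound 2 to compound 4 (0.01 log units; within the scatter), and this change also carries across: the same change on two cores in this assay, a 1.4-fold lower number (0.16 log units; within the scatter) from compound 1 to compound 3 and a 1.0-fold lower number (0.01 log units; within the scatter) from compound 2 to compound 4, 1.4-fold (0.14 log units) apart, within the scatter of two such steps This shows that both changes carried over within this one set of four compounds, but it does not show that they would carry to other cores, and it gives no reason for the agreement.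

The compounds shown leave open how a fluoro or methoxy group at the same ring place would compare. They also leave open whether a morpholine or a longer chain would follow the same pattern.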